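A Urea in Place of the Benzamide: Compound 4 Foreseen

The source may report more compounds than this note shows. Statements on the series, on what has been measured and on what is new or still open speak of the compounds shown alone.

Compound 1: `CC(C)C(NC(=O)c1ccccc1)C(=O)N1CCC(c2ccc(F)cc2)CC1` — 423 nM
Compound 2: `CC(C)[C@@H](NC(=O)c1cccc(F)c1)C(=O)N1CCC(c2ccc(Cl)cc2)CC1` — 24 nM
Compound 3: `CC[C@@H](NC(=O)CCc1ccccc1)C(=O)N1CCC(c2ccc(Cl)cc2)CC1` — 85 nM

In an assay on THP-1 cells for displacement of a labelled ligand from C-C chemokine receptor type 1 (Homo sapiens) (on this read-out higher numbers stand for weaker inhibition and lower numbers for stronger inhibition), compound 2 gives the lowest of the three numbers shown. Compound 3 stands nearest to it, with a higher value that lies beyond the scatter, and compound 1 stands furthest, also beyond the scatter. Compound 2 is therefore the strongest inhibitor of the three on this read-out.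

Compound 4 is `CC(C)[C@@H](NC(=O)Nc1ccccc1)C(=O)N1CCC(c2ccc(Cl)cc2)CC1`. It keeps the shared core of compound 2 and differs in one place: anilino in place of 3-fluorophenyl on a carbonyl carbon. Going by the values given here, no pair of measured compounds shows this kind of change, so the size of the step has to be guessed from the change itself rather than from a measured precedent. The expectation is a modest loss, a step of a 2.5-fold higher number from compound 2 to compound 4 (0.40 log units; beyond the scatter) in this assay that may or may not clear the scatter. Compound 4 is accordingly estimated at 60 nM, with a range from 20 nM to 200 nM.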

Compound 4, half-maximal inhibitory concentration: 616 nM
Compound 4: middle estimate off by 10-fold (1.01 log units), on the low side; measured number above the stated range.
By their numbers in this assay, from the lowest: compound 2; then compound 3; then compounds 1 and 4 (each within the scatter of the next).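

In this assay, going by these compounds alone, the change from (3-fluorophenyl)carbonyl to phenylcarbamoyl gives a 26-fold higher number from compound 2 to compound 4 (1.41 log units; beyond the scatter) and is the first step that differs in one place. It shows that inhibition is highly sensitive to the group on this carbonyl carbon, even when the leaving and entering groups have the same heavy-atom count and each holds one six-membered aromatic ring of carbon only. No measured evidence is available to explain the size of this step.

The compounds shown leave open whether the step follows from the nitrogen that enters, with its hydrogen-bond donor, or from the fluorine that leaves. A 3-fluoroanilino group on this carbonyl carbon would separate those two changes, and a benzyl group there would test a carbon in place of that nitrogen.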